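Fluoro for Bromo: Estimating Compound 4

The source may hold more compounds than are shown below. What is called first, only, known or untested is meant among the compounds shown, and "the series" means these compounds.

Measured compounds:
compound 1, `CCOC(=O)C1=C(Nc2ccccc2)S/C(=C\c2cc(OC)c(O)c(OC)c2)C1=O`: 57.5%
compound 2, `CCOC(=O)C1=C(Nc2ccc(OC)cc2)S/C(=C\c2ccc[nH]2)C1=O`: 27.6%
compound 3, `CCOC(=O)C1=C(Nc2ccc(Br)cc2)S/C(=C\c2ccc[nH]2)C1=O`: 41.5%

In a functional assay on JAR cells (Homo sapiens) for inhibition, read by MTT assay, with a stated time of 72 h, tested at 10 uM (on this read-out lower numbers stand for less inhibition and higher numbers for more inhibition at the one concentration tested (going by the name of the read-out)), compound 3 holds the second highest of the three numbers. Its nearest neighbour is compound 2, lower by a step that is beyond the scatter, and the furthest is compound 1, which is higher, again beyond the scatter. Compound 4, `CCOC(=O)C1=C(Nc2ccc(F)cc2)S/C(=C\c2ccc[nH]2)C1=O`, differs from compound 3 in one place: fluoro in place of bromo on an aromatic carbon.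

Among the compounds with values here, only one measured step bears on this change, and only loosely. The step of a number 13.9 percentage points higher from compound 2 to compound 3 (beyond the scatter) shows that the group on that aromatic carbon matters in this assay, but it concerns bromo against methoxy, not bromo against fluoro. Within the data shown here, no pair among the measured compounds isolates a fluoro-for-bromo change, so the direction cannot be read directly from the data. Since compound 3 with bromo stands above compound 2, and fluoro is the smaller of the two halogens, a modest move downward from compound 3, or no step beyond the scatter, is the most reasonable expectation.

Compound 4 is therefore estimated at 35%, between 22% and 50%. The expected step is a number 6.5 percentage points lower from compound 3 to compound 4 (within the scatter).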

Compound 4, a percentage reported as inhibition, at one concentration (the size of the read-out at that concentration, not a potency): 61.5%
Estimate against measurement, compound 4: 26.5 percentage points below; the whole stated range lies below it.
By their numbers in this assay, from the lowest: compound 2; then compound 3; then compounds 1 and 4 (each within the scatter of the next).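

The change from bromo to fluoro on this aromatic carbon is not a neutral swap of one halogen for another: in this assay it gives a number 20 percentage points higher from compound 3 to compound 4 (beyond the scatter) and so counts as a real change at this position. Set against the methoxy compound, fluoro gives a number 33.9 percentage points higher from compound 2 to compound 4 (beyond the scatter) and thus a larger gain than bromo gave, which shows that the earlier step from methoxy to bromo captured only part of the range this position can span. Among these three compounds, which differ only in this one group, the numbers rise from methoxy through bromo to fluoro with every step beyond the scatter, and nothing available here speaks to why the order runs this way.

On these data alone, with only these three groups seen at this carbon, it remains open where chloro, an amine or a carboxylic acid would fall in that order. As far as these compounds go, it is also open whether fluoro would bring a similar gain on the core of compound 1, whose other aromatic group differs from that of compound 4.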